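This account rests on a few compounds, and the source may have more. Where it says the series, first, only, none or still open, it means among the compounds named here.

Working notes on the series. In a functional assay on A549 cells (Homo sapiens) for inhibition, read by MTT assay, with a stated time of 24 h (a lower number here means a stronger inhibitor, a higher number a weaker inhibitor), compound 1 `COc1ccc(-n2cc(CN3C(=O)C[C@@H]4CC[C@@]3(C)C4(C)C)nn2)cc1` gives 50 nM. Compound 2 `CC1(C)[C@H]2CC[C@]1(C)N(Cc1cn(-c3ccc(C#N)cc3)nn1)C(=O)C2` gives 140 nM in this assay, the step being a 2.8-fold higher number from compound 1 to compound 2 (0.45 log units; beyond the scatter). Compound 3 `COc1cccc(-n2cc(CN3C(=O)C[C@@H]4CC[C@@]3(C)C4(C)C)nn2)c1` gives 240 nM in this assay, the highest of the three numbers: a 4.8-fold higher number from compound 1 to compound 3 (0.68 log units; beyond the scatter), while a 1.7-fold higher number from compound 2 to compound 3 (0.23 log units; within the scatter). Compound 4 `Cc1cccc(-n2cc(CN3C(=O)C[C@@H]4CC[C@@]3(C)C4(C)C)nn2)c1` differs from compound 3 in one place: methyl in place of methoxy on an aromatic carbon. Within the data shown here, no measured pair exchanges methoxy for methyl; the only replacement at an aromatic carbon so far, a 2.8-fold higher number from compound 1 to compound 2 (0.45 log units; beyond the scatter), was modest, and the remaining steps move the group round the ring. Compound 4 is therefore expected to sit near compound 3, the estimated step of a 1.3-fold higher number from compound 3 to compound 4 (0.10 log units; within the scatter) lying within the scatter. The estimate for compound 4 in this assay is 300 nM, range 120 nM to 800 nM.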

Compound 4, half-maximal inhibitory concentration: 50 nM
Compound 4: the middle estimate sits 6.0-fold (0.78 log units) above what was measured; the measured number lies below the stated range.
By their numbers in this assay, from the lowest: compounds 1 and 4 (each within the scatter of the next); then compounds 2 and 3 (each within the scatter of the next).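

In this assay the exchange of methoxy for methyl on an aromatic carbon meta to a large group is not silent: a 4.8-fold lower number from compound 3 to compound 4 (0.68 log units; beyond the scatter) shows that the group itself matters here, not only its place on the ring. The 3-methylphenyl group matches the 4-methoxyphenyl group with no change at the digits printed from compound 1 to compound 4 (within the scatter) and stands apart from the 4-cyanophenyl group with a 2.8-fold lower number from compound 2 to compound 4 (0.45 log units; beyond the scatter) in the same assay. No evidence in hand explains this step. Open, as far as these compounds go, is whether an ethyl, an amine or a hydroxyl on this carbon would hold the number of compound 4.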